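The source may hold more compounds than are shown below. What is called first, only, known or untested is meant among the compounds shown, and "the series" means these compounds.

Measured compounds:
compound 1 `O=C(Cn1nnc(-c2ccccc2)n1)NC1CC2CCC1C2` — 13%
compound 2 `Cc1cc(NC(=O)Cn2nnc(-c3ccccc3)n2)n(C(C)C)n1` — 107%
compound 3 `Cc1cc(NC(=O)Cn2nnc(-c3cccc(Cl)c3)n2)n(C2CCCCC2)n1` — 89%

In an assay on HEK293 cells for activation of Kir3.1/Kir3.2 (Homo sapiens), read by thallium flux (on this read-out higher numbers stand for larger maximal responses and lower numbers for smaller maximal responses), compound 3 stands second highest of the three numbers. Its nearest neighbour is compound 2, which gives a number higher by a margin beyond the usual scatter, and the furthest is compound 1, which gives a number far lower, again beyond the scatter. Compound 4 `Cc1cc(NC(=O)Cn2nnc(-c3cccc(F)n3)n2)n(C2CCCCC2)n1` has not yet been measured. It differs from compound 3 in one place: 6-fluoropyridin-2-yl in place of 3-chlorophenyl on an aromatic carbon. Among the compounds with values here, no step between measured compounds shows such a change, so the account rests on the standing of compound 3 alone. For compound 4 a modest downward step from compound 3 is expected, a number 14 percentage points lower from compound 3 to compound 4 (beyond the scatter). The expected value for compound 4 in this assay is 75%, with a range from 40% to 105%.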

Compound 4, largest response reached (Emax), in percent of the reference or control that the assay uses: > 83%
Compound 4 ended at the assay's limit; the forecaster's own chance of this, stated with the estimate: 0%; middle value at least 8 percentage points from the limit.
By their numbers in this assay, from the lowest: compound 1; then compound 3; then compound 2.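

In this assay compound 4 gives > 83%, which is a limit of the assay and not a number. Within the data shown here, no step from compound 3 to compound 4 can be read. The compounds shown leave open how large the effect on the maximal response is of 6-fluoropyridin-2-yl in place of 3-chlorophenyl.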